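A few compounds are considered here, and "the series" means these few. Any claim that something is new, unique, unknown or untested is made for them only; others in the source may bear on it.

Compound 1, `O=C(Nc1cccc(-n2cc(-c3ccncc3)c(-c3ccc(Cl)c(O)c3)n2)c1)Nc1cc(C(F)(F)F)cc(C(F)(F)F)c1`: 2590 nM
Compound 2, `COc1cc(-c2nn(-c3cccc(NC(=O)Nc4cccc(C(F)(F)F)c4)c3)cc2-c2ccncc2)ccc1Cl`: 2140 nM
Compound 3, `COc1cc(-c2nn(-c3cccc(NC(=O)c4ccccc4)c3)cc2-c2ccncc2)ccc1Cl`: 551 nM

For the measured compounds named here, in a functional assay on MDA-MB-435 cells (Homo sapiens) for inhibition, read by sulforhodamine B assay, with a stated time of 48 h (a higher number here means a weaker inhibitor of growth, a lower number a stronger inhibitor of growth), compound 2 stands second highest of the three numbers: compound 1 lies within the scatter of it, while compound 3 gives a number lower by a 3.9-fold lower number from compound 2 to compound 3 (0.59 log units; beyond the scatter), the only single-place step among the measured compounds. Compound 4, `COc1cc(-c2nn(-c3cccc(NC(=O)Nc4cc(C(F)(F)F)cc(C(F)(F)F)c4)c3)cc2-c2ccncc2)ccc1Cl`, is not yet measured; it differs from compound 2 by trifluoromethyl in place of hydrogen on an aromatic carbon.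

Going by the values given here, no measured step changes this same place. The step from compound 2 to compound 3 concerns the carbonyl substituent and does not bear on it. Compound 1, which carries the same two trifluoromethyl groups as compound 4 but also differs from compound 2 in a second place, gives a number within the scatter of compound 2, so what the two values show is no clear shift. The step from compound 2 to compound 4 is therefore expected to be small, about a 1.1-fold higher number from compound 2 to compound 4 (0.03 log units; within the scatter), in no particular direction beyond the scatter. Compound 4 is estimated at 2300 nM, between 1000 nM and 5500 nM.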

Compound 4, concentration for total growth inhibition: 1990 nM
Estimate against measurement, compound 4: 1.2-fold (0.06 log units) above; measured number inside the range.
By their numbers in this assay, from the lowest: compound 3; then compounds 4, 2 and 1 (each within the scatter of the next).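

In this assay, for the compounds shown here, the first direct reading at this place comes from trifluoromethyl in place of hydrogen on an aromatic carbon, meta to a trifluoromethyl group, which gives a 1.1-fold lower number from compound 2 to compound 4 (0.03 log units; within the scatter) and so shows no clear shift. The change on the oxygen can now also be read by itself: methyl in place of hydrogen on an oxygen on an aromatic ring gives a 1.3-fold lower number from compound 1 to compound 4 (0.11 log units; within the scatter), so neither change alone moves the number beyond the scatter, which compound 1 and compound 2, differing in both places, could not show. Nothing available bears on why these two changes leave the number where it is.

Open, on these data alone, is whether a different group at this place, such as an amine, a carboxylic acid or a nitrile, would shift the number. Also open, as far as these compounds go, is whether either change would remain as small on compound 3, which carries phenyl on the carbonyl carbon.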